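The source may report more compounds than this note shows. Statements on the series, on what has been measured and on what is new or still open speak of the compounds shown alone.

Measured so far in a functional assay, with a stated time of 30 min, in the absence of a further agent; a lower number here means a stronger inhibitor, a higher number a weaker inhibitor

compound 1 `Cc1ccc(C(=O)Nc2nnc(-c3ccc(O)c(O)c3)s2)cc1` gives 34000 nM
compound 2 `O=C(COc1ccccc1)Nc1nnc(-c2ccc(O)c(O)c2)s1` gives 36100 nM
compound 3 `O=C(Nc1nnc(-c2ccc(O)c(O)c2)s1)c1ccc(Cl)cc1` gives 53000 nM

Compound 3 (53000 nM) cannot be separated from the other two measured compounds. Its steps are a 1.6-fold higher number from compound 1 to compound 3 (0.19 log units; within the scatter) and a 1.5-fold higher number from compound 2 to compound 3 (0.17 log units; within the scatter), and the remaining pair is no wider, with a 1.1-fold higher number from compound 1 to compound 2 (0.03 log units; within the scatter). The three values therefore form a single flat group.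

Next is compound 4 `O=C(Nc1nnc(-c2ccc(O)c(O)c2)s1)c1ccccc1`, which carries hydrogen in place of chloro on an aromatic carbon, para to a large group (hydrogen in place of chloro on an aromatic carbon). The same difference reads 4-chlorophenyl to phenyl.

The closest measured precedent is the exchange at this same place, chloro in place of methyl, which gave a 1.6-fold higher number from compound 1 to compound 3 (0.19 log units; within the scatter). The wider exchange of the whole group on the carbonyl carbon also stayed small, with a 1.5-fold higher number from compound 2 to compound 3 (0.17 log units; within the scatter). Within the data shown here, no measured compound has hydrogen at this place, so the precedent is indirect.

No step beyond the scatter is expected in this assay, and no direction can be assigned with confidence. The expected step is small (a 1.3-fold lower number from compound 3 to compound 4 (0.10 log units; within the scatter)). The estimated value for compound 4 is 42000 nM, with an expected range from 20000 nM to 85000 nM.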

Compound 4, half-maximal inhibitory concentration: 23400 nM
Estimate against measurement, compound 4: 1.8-fold (0.25 log units) above; the range from low to high includes it.
By their numbers in this assay, from the lowest: compounds 4, 1, 2 and 3 (each within the scatter of the next, the first and the last beyond it).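

Among these compounds, on an aromatic carbon para to a large group, hydrogen in place of chloro gives the only step in this short series that lies beyond the scatter in this assay (a 2.3-fold lower number from compound 3 to compound 4 (0.36 log units; beyond the scatter)), so this assay can register a change at this place, though the step is modest. The separation is confined to that pair: hydrogen in place of methyl at the same place stays within the scatter (a 1.5-fold lower number from compound 1 to compound 4 (0.16 log units; within the scatter)), as does phenyl in place of phenoxymethyl on the carbonyl carbon (a 1.5-fold lower number from compound 2 to compound 4 (0.19 log units; within the scatter)), so the series forms a shallow run rather than two distinct groups. No available measurement accounts for the step from chloro to hydrogen.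

Still open, as far as these compounds go, is whether any other group at this place, such as an amine, a methoxy group or a carboxylic acid, would give a step clearly beyond the scatter from compound 4, since only hydrogen, methyl and chloro appear there. From the compounds shown here alone, the shared core is constant throughout, so the effect of a single hydroxy group in place of its two, or of a longer chain on the carbonyl carbon, remains unknown.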